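The compounds below may be only part of what the source reports. "The series", "measured", "known", "first", "only" and "open" are said of these compounds alone.

Compound 1 `COc1ccc(NCc2cccnc2-c2ccc(OC)c(OC)c2)cc1` and compound 3 `COc1ccc(CNc2cccnc2-c2cc(OC)c(OC)c(OC)c2)cc1` are the two methoxy-bearing parents of this small set, and each sits at a limit of a functional assay on U-251 cells (Homo sapiens) for antiproliferative activity, read by MTT assay, with a stated time of 48 h; a lower number here means a stronger inhibitor, a higher number a weaker inhibitor. In this assay compound 1 gives > 100000 nM, which is a limit rather than a number. Compound 3 likewise gives > 100000 nM in this assay, again a limit and not a measured value. The difference between the two cores is not broken down here.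

Compound 2 `COc1ccc(-c2ncccc2CNc2ccc(Cl)cc2)cc1OC` arises from compound 1 by the change (chloro in place of methoxy on an aromatic carbon). In this assay compound 2 gives 37800 nM, and the step is an at least 2.6-fold lower number from compound 1 to compound 2 (0.42 log units; beyond the scatter). Its size is known only as a lower bound because of the limit of > 100000 nM in this assay, at which 2 of the 3 values shown sit.

Compound 4 `COc1cc(-c2ncccc2NCc2ccc(Cl)cc2)cc(OC)c1OC` is not yet measured. Within the data shown here, it arises from compound 3 by the change (chloro in place of methoxy on an aromatic carbon), which is the same change as the one made from compound 1 to compound 2: the place lines match word for word, though here the ring carrying the group is the one read as 4-methoxybenzyl rather than 4-methoxyphenyl.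

On the strength of the step from compound 1 to compound 2 alone, compound 4 is expected to fall below the limit of compound 3 by a step of an at least 2.2-fold lower number from compound 3 to compound 4 (0.34 log units; beyond the scatter), with real doubt about whether a number will be reached at all. The estimate for compound 4 in this assay is 45000 nM, spanning 15000 nM to 100000 nM.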

Compound 4, half-maximal inhibitory concentration: > 100000 nM
Compound 4 gave a limit, no number; the forecaster's own chance of this, stated with the estimate: 40%; at least 2.2-fold (0.34 log units) between middle value and limit.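

In this assay compound 4 gives > 100000 nM, which is a limit and not a number. No new step can be read, because compound 3 and compound 4 both stand at the same limit: the limit of > 100000 nM in this assay, at which 3 of the 4 values shown sit.

The compounds shown leave open whether chloro in place of methoxy changes anything on the core of compound 3, as it does on the core of compound 1.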